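This account rests on a few compounds, and the source may have more. Where it says the series, first, only, none or still open, it means among the compounds named here.

Of the compounds shown here, two have been tested so far in an ADME assay on L929 cells (Mus musculus) for cytotoxicity, read by resazurin assay, with a stated time of 72 h; on this read-out lower numbers stand for stronger inhibition and higher numbers for weaker inhibition. Compound 1 `OB1OCc2ccc(-n3cc(Sc4ccccc4O)c4ccccc43)cc21` returns > 10 ug/mL there, which is a limit of the assay rather than a number. Compound 2 `O=C(c1ccc(Cl)cc1)c1ccn(-c2ccc3c(c2)B(O)OC3)c1` likewise returns > 10 ug/mL in this assay, again a limit and not a number. Within the data shown here, compound 2 therefore stands where every value so far stands, namely at the limit of > 10 ug/mL in this assay, at which 2 of the 2 values shown sit, and no step between the two measured compounds can be read off.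

Compound 3 `O=C(c1ccn(-c2ccc3c(c2)B(O)OC3)c1)C1CCCCC1` has not yet been measured. It differs from compound 2 by cyclohexyl in place of 4-chlorophenyl on a carbonyl carbon, with the shared core otherwise kept. Among the measured compounds shown here, neither measured compound gave a number, so there is no measured step to lean on; the expectation is a step that the limit leaves unreadable from compound 2 to compound 3, no larger than the usual scatter. Compound 3 is accordingly expected to give about 20 ug/mL, within a range of 8 ug/mL to 50 ug/mL, and most likely to be reported once more only as a limit.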

Compound 3, half-maximal inhibitory concentration: > 10 ug/mL
Compound 3 was reported as a limit; the forecaster's own chance of this, stated with the estimate: 75%; the middle value does not contradict the limit.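

Compound 3 gives > 10 ug/mL in this assay, which is a limit and not a number. Among these compounds, compound 2 also sits at a limit, so no step between compound 2 and compound 3 can be read. The compounds shown leave open whether cyclohexyl and 4-chlorophenyl on a carbonyl carbon differ at all in this assay.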